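Swapping a benzyl group for a sulfonyl on the core

The source may report more compounds than this note shows. Statements on the series, on what has been measured and on what is new or still open speak of the compounds shown alone.

Measured so far:
- compound 1, `Nc1nc2c(c(=O)n(CC3CC3)c(=O)n2CC2CC2)n1Cc1ccccc1`, 27%
- compound 2, `COc1ccc(Cn2c(N)nc3c2c(=O)n(CC2CC2)c(=O)n3CC2CC2)cc1`, 60%
- compound 3, `Nc1nc2c(c(=O)n(CC3CC3)c(=O)n2CC2CC2)n1Cc1cccc2ccccc12`, 0%

In an assay on isolated protein with dual specificity calcium/calmodulin-dependent 3',5'-cyclic nucleotide phosphodiesterase 1B (Bos taurus) as the target, tested at 100 uM (a higher number here means more inhibition at the concentration tested (going by the name of the read-out), a lower number less inhibition), compound 2 stands highest of the three, with compound 1 closest, a number 33 percentage points higher from compound 1 to compound 2 (beyond the scatter), and compound 3 furthest, a number 60 percentage points lower from compound 2 to compound 3 (beyond the scatter). The step from compound 1 to compound 3 also went down, a number 27 percentage points lower from compound 1 to compound 3 (beyond the scatter). All three steps change the group on the aromatic nitrogen, and each change there moved the number beyond the scatter.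

Compound 4, `Cc1ccc(S(=O)(=O)n2c(N)nc3c2c(=O)n(CC2CC2)c(=O)n3CC2CC2)cc1`, has not been measured. It differs from compound 2 as follows: (4-methylphenyl)sulfonyl in place of 4-methoxybenzyl on an aromatic nitrogen. Within the data shown here, no measured step exchanges a benzyl-type group for a sulfonyl, so the bearing of the known steps is indirect: they show that this position is sensitive, and that the methoxy-bearing group gave the highest number while a larger aromatic group gave the lowest.

The expectation for compound 4 in this assay is therefore a drop, a number 35 percentage points lower from compound 2 to compound 4 (beyond the scatter), with wide uncertainty. The estimated value for compound 4 is 25%, within a range from 0% to 55%.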

Compound 4, a percentage reported as inhibition, at one concentration (the size of the read-out at that concentration, not a potency): 9%
Compound 4: middle estimate off by 16 percentage points, on the high side, and the stated range covers the measured number.
By their numbers in this assay, from the lowest: compounds 3 and 4 (each within the scatter of the next); then compound 1; then compound 2.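

In this assay, the change of link on this aromatic nitrogen lowers the number against the methoxy-bearing group, with a number 51 percentage points lower from compound 2 to compound 4 (beyond the scatter), and also against plain benzyl, with a number 18 percentage points lower from compound 1 to compound 4 (beyond the scatter). Both groups that leave and the group that enters carry one six-membered aromatic ring of carbon only, so keeping such a ring here does not by itself hold the number up, and compound 4 sits within the scatter of compound 3. The data at hand offer no measurement that accounts for these drops.

The step from compound 2 also swaps methoxy for methyl, so the effect of the sulfonyl link cannot be separated from that of the ring substituent; 4-methylbenzyl would help to separate them. Going by these compounds, it also stays open how a group without an aromatic ring, such as a longer chain ending in an amine, would behave at this nitrogen.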